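A few compounds are considered here, and "the series" means these few. Any claim that something is new, unique, unknown or untested is made for them only; others in the source may bear on it.

Measured compounds:
Compound 1, `CO/N=C/c1c(N)ncnc1Oc1ccc2cccnc2c1`: 886 nM
Compound 2, `COCCO/N=C/c1c(N)ncnc1Oc1ccc2[nH]c(C)cc2c1F`: 233 nM

In a functional assay on A-375 cells (Homo sapiens) for antiproliferative activity (a higher number here means a weaker inhibitor, a lower number a stronger inhibitor), compound 2 gives the lower of the two numbers, and compound 1 gives 886 nM, a gap beyond the usual scatter, so compound 2 is the stronger inhibitor of the pair. Compound 3, `Cc1cc2c(F)c(Oc3ncnc(N)c3/C=N/OCc3ccccc3)ccc2[nH]1`, has not yet been measured. It differs from compound 2 by phenyl in place of methoxymethyl on a saturated chain carbon bound to an oxygen on an unsaturated carbon. No measured pair isolates this change, so nothing shown sets its size or direction. The step from compound 2 to compound 3 is expected to be small, a 1.3-fold higher number from compound 2 to compound 3 (0.11 log units; within the scatter), likely within the scatter. Compound 3 is estimated at 300 nM, in the range 80 nM to 1200 nM.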

Compound 3, half-maximal inhibitory concentration: 62 nM
Beside the measured number, compound 3's estimate is 4.8-fold (0.68 log units) above it; measured number below the stated range.
By their numbers in this assay, from the lowest: compound 3; then compound 2; then compound 1.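

In this assay, the change from 2-methoxyethoxy to benzyloxy gives a 3.8-fold lower number from compound 2 to compound 3 (0.57 log units; beyond the scatter) and makes compound 3 the stronger inhibitor of the pair. This position therefore accepts a six-membered aromatic ring of carbon only in place of methoxymethyl, and the change moves the number beyond the scatter. No data shown here account for the gain. The compounds shown leave open how a longer chain carrying the phenyl would read at this position. They also leave open the effect of an amine or a carboxylic acid on that phenyl.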